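Swapping Fluoro for Methyl on the Aryl Oxadiazole Arm

A few compounds are considered here, and "the series" means these few. Any claim that something is new, unique, unknown or untested is made for them only; others in the source may bear on it.

In an ADME assay on HepG2 cells (Homo sapiens) for cytotoxicity, read by MTT assay, with a stated time of 48 h (on this read-out lower numbers stand for higher toxicity in this test and higher numbers for lower toxicity in this test), compound 1 `CC(=O)OC[C@H]1O[C@H](OC[C@@H](Cn2cc(CN(c3nc(-c4cccc([N+](=O)[O-])c4)no3)C3CCCCC3)nn2)OC(C)=O)C=C[C@@H]1OC(C)=O` gives only a limit, > 200 ug/mL. For the measured compounds named here, compound 2 `CC(=O)OC[C@H]1O[C@H](OC[C@@H](Cn2cc(CN(c3nc(-c4ccc(F)cc4)no3)C3CCCCC3)nn2)OC(C)=O)C=C[C@@H]1OC(C)=O` gives 28.8 ug/mL in this assay, the one actual number in this set. Compound 3 `CC(=O)OC[C@H]1O[C@H](OC[C@@H](Cn2cc(CN(c3nc(-c4ccc(C)cc4)no3)C3CCCCC3)nn2)OC(C)=O)C=C[C@@H]1OC(C)=O` differs from compound 2 by methyl in place of fluoro on an aromatic carbon. Going by the values given here, the single measured step, an at least 6.9-fold lower number from compound 1 to compound 2 (0.84 log units; beyond the scatter), involved a different group on a different aryl pattern, so no measured step tests a methyl against a fluoro. The step expected here, a 1.0-fold higher number from compound 2 to compound 3 (0.02 log units; within the scatter), is therefore none beyond the scatter. Compound 3 is estimated at 30 ug/mL, with a range of 10 ug/mL to 90 ug/mL.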

Compound 3, half-maximal cytotoxic concentration: 36.8 ug/mL
The estimate for compound 3 lay 1.2-fold (0.09 log units) below the measured number; low and high end bracket the measured number.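

Methyl in place of fluoro, para to a large group, gives a 1.3-fold higher number from compound 2 to compound 3 (0.11 log units; within the scatter), so this assay does not separate these two groups at this position. A second group now also falls well short of the 3-nitrophenyl compound, with 4-methylphenyl in its place giving an at least 5.4-fold lower number from compound 1 to compound 3 (0.73 log units; beyond the scatter). Compound 1 remains a limit of the assay, not a number: the limit of > 200 ug/mL in this assay, at which 1 of the 3 values shown sits.

In both steps from compound 1, the nitro group and its ring position change together, so a 4-nitrophenyl compound would be needed to separate them. Going by these compounds, how an amine or a carboxylic acid at this position would read also stays open.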